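Carbamate ester change on the shared core

This account rests on a few compounds, and the source may have more. Where it says the series, first, only, none or still open, it means among the compounds named here.

Compound 1 `CC(C)(C)OC(=O)N1CCC(O[C@H]2CC[C@H](Oc3ccc(S(C)(=O)=O)cc3)CC2)CC1`, compound 2 `CC(C)(C)OC(=O)N1CCC(O[C@H]2CC[C@H](Oc3ccc(C#N)cc3)CC2)CC1` and compound 3 `CC(C)(C)OC(=O)N1CCC(O[C@H]2CC[C@H](Oc3cnc(S(C)(=O)=O)cn3)CC2)CC1` share one core and differ only at the aryl ether end. In a functional assay on isolated protein for agonist activity at Glucose-dependent insulinotropic receptor (Homo sapiens), read by HTRF and cAMP accumulation (a higher number here means a larger maximal response, a lower number a smaller maximal response), compound 1 gives 115%, compound 2 gives 116% and compound 3 gives 110%. The three steps among them are a number 1 percentage points higher from compound 1 to compound 2 (within the scatter), a number 5 percentage points lower from compound 1 to compound 3 (within the scatter) and a number 6 percentage points lower from compound 2 to compound 3 (within the scatter). For the measured compounds named here, compound 3 therefore stands within the scatter of both compound 1 and compound 2, and no pair among the three is separated beyond the scatter.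

Compound 4 `CC1(OC(=O)N2CCC(O[C@H]3CC[C@H](Oc4cnc(S(C)(=O)=O)cn4)CC3)CC2)CC1` keeps the aryl ether of compound 3 and changes the other end: 1-methylcyclopropyl in place of tert-butyl on an oxygen next to a carbonyl group. Going by the values given here, none of the measured steps touches this position; all three concern the aryl ether and all three lie within the scatter. Among the compounds with values here, no measured step in this assay bears directly on the change, so the expected step is no change at the digits printed from compound 3 to compound 4 (within the scatter), none beyond the scatter in either direction. Compound 4 is expected to give 110% in this assay, with a range from 98% to 122%.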

Compound 4, largest response reached (Emax), in percent of the reference or control that the assay uses: 118%
Compound 4: middle estimate off by 8 percentage points, on the low side; measured number inside the range.
By their numbers in this assay, from the lowest: compounds 3, 1, 2 and 4 (each within the scatter of the next).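

For the compounds shown here, the carbamate ester end, which none of the earlier steps touched, now has one reading in this assay: 1-methylcyclopropyl in place of tert-butyl on an oxygen next to a carbonyl group is a number 8 percentage points higher from compound 3 to compound 4 (within the scatter) and so does not separate the two esters. The swap brings in a three-membered ring of carbon with no change in the number of heavy atoms, and the maximal response stays within the scatter with the 5-(methylsulfonyl)pyrazin-2-yl ether held fixed. Nothing available here explains the reading at this end.

On these data alone, this rests on a single pair, so it remains open whether the same swap reads alike with the 4-cyanophenyl or 4-(methylsulfonyl)phenyl ether. Also open, as far as these compounds go, is how this end responds to a larger change, such as a 1-(trifluoromethyl)cyclopropyl ester or a urea in place of the carbamate.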